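The source may hold more compounds than are shown below. What is called first, only, known or untested is meant among the compounds shown, and "the series" means these compounds.

Measured so far:
compound 1 `COc1ccc(-c2nnc(NC(=O)/C=C/c3ccc(F)cc3)s2)cc1`: 0.75 ug/mL
compound 2 `COc1ccc(-c2nnc(NC(=O)/C=C/c3ccccc3)s2)cc1`: 0.68 ug/mL

For the measured compounds named here, in a functional assay on A549 cells (Homo sapiens) for antiproliferative activity, read by MTT assay, with a stated time of 48 h (on this read-out higher numbers stand for weaker inhibition and lower numbers for stronger inhibition), compound 2 gives 0.68 ug/mL and compound 1 gives 0.75 ug/mL; the two lie within the scatter of each other, so compound 2 has no clear standing above or below its only neighbour.

Next is compound 3 `COc1ccc(-c2nnc(NC(=O)/C=C/c3ccc(C(F)(F)F)cc3)s2)cc1`, with trifluoromethyl in place of hydrogen on an aromatic carbon, para to a large group: trifluoromethyl in place of hydrogen on an aromatic carbon.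

Going by the values given here, only one measured step bears on this: a 1.1-fold lower number from compound 1 to compound 2 (0.04 log units; within the scatter). It exchanges fluoro and hydrogen on the same carbon and stays within the scatter. Among the compounds with values here, no trifluoromethyl compound has been measured, so this evidence is thin and the range is kept wide.

On that single step, no change beyond the scatter is expected, and the expected step is a 1.2-fold higher number from compound 2 to compound 3 (0.07 log units; within the scatter).

For compound 3 the estimated value is 0.8 ug/mL, with an expected range of 0.3 ug/mL to 2 ug/mL.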

Compound 3, half-maximal inhibitory concentration: 0.69 ug/mL
Compound 3: middle estimate off by 1.2-fold (0.06 log units), on the high side, within the range that was stated.
By their numbers in this assay, from the lowest: compounds 2, 3 and 1 (each within the scatter of the next).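

In this assay, the aromatic carbon para to a large group now carries a group of 4 heavy atoms, and trifluoromethyl in place of hydrogen gives no change beyond the scatter (a 1.0-fold higher number from compound 2 to compound 3 (0.01 log units; within the scatter)). Trifluoromethyl in place of fluoro likewise stays within the scatter (a 1.1-fold lower number from compound 1 to compound 3 (0.04 log units; within the scatter)), so across compounds 1, 2 and 3 neither the fluoro nor the bulkier trifluoromethyl separates from hydrogen at this carbon. No measurement available here accounts for this flat result.

On these data alone, the three compounds carry only hydrogen, fluoro and trifluoromethyl at this carbon, so it remains open whether an amine, a carboxylic acid or a longer alkyl chain would leave the number unchanged. The methoxy group and the amide hydrogen are the same in all three compounds, so nothing here bears on their contribution.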